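A few compounds are considered here, and "the series" means these few. Any claim that something is new, unique, unknown or untested is made for them only; others in the source may bear on it.

Compounds measured so far in a physicochemical assay for solubility, measured as kinetic solubility; on this read-out higher numbers stand for higher solubility and lower numbers for lower solubility:

compound 1, `CNc1nccc(N2CC[C@H](NC(=O)Nc3ccc(Cl)c(C(F)(F)F)c3)C2)n1`: 22200 nM
compound 2, `CNc1nccc(N2CC[C@H](NC(=O)Nc3ccc(CN(C)C)c(C(F)(F)F)c3)C2)n1`: 102000 nM
compound 3, `CNc1nccc(N2CC[C@H](NC(=O)Nc3ccc(C)c(Cl)c3)C2)n1`: 72700 nM

Compound 2 holds the highest number of the three in this assay. Its nearest neighbour is compound 3, whose number is within the scatter of it, so no order between compound 2 and compound 3 can be read; compound 1 sits furthest away, beyond the scatter. Within the data shown here, the one single-point step that can be read is a 4.6-fold higher number from compound 1 to compound 2 (0.66 log units; beyond the scatter).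

Compound 4, `CNc1nccc(N2CC[C@H](NC(=O)Nc3ccc(CN4CCN(C)CC4)c(C(F)(F)F)c3)C2)n1`, is not yet measured. It differs from compound 2 in one place: 4-methylpiperazin-1-yl in place of dimethylamino on a saturated chain carbon bound to an aromatic carbon. Among the measured compounds shown here, no measured pair changes this same position in this same way, so the step from compound 1 to compound 2 bears only indirectly: it shows that the numbers in this assay can move by that much when the group on this part of the aryl ring is exchanged. With nothing closer to go on, a step of no more than the usual scatter is expected, slightly upward if anything, as a 1.2-fold higher number from compound 2 to compound 4 (0.07 log units; within the scatter). Compound 4 is therefore estimated at 120000 nM, in the range 50000 nM to 280000 nM.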

Compound 4, solubility: 67500 nM
Compound 4: middle estimate off by 1.8-fold (0.25 log units), on the high side; the measured number falls inside the stated range.
By their numbers in this assay, from the lowest: compound 1; then compounds 4, 3 and 2 (each within the scatter of the next).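

In this assay, the larger exchange at this position, the step of a 1.5-fold lower number from compound 2 to compound 4 (0.18 log units; within the scatter), stays within the scatter, so dimethylamino and 4-methylpiperazin-1-yl on the saturated chain carbon cannot be told apart. The gain over the chloro compound is therefore not confined to one amine: the step of a 3.0-fold higher number from compound 1 to compound 4 (0.48 log units; beyond the scatter) lies beyond the scatter, as does the step of a 4.6-fold higher number from compound 1 to compound 2 (0.66 log units; beyond the scatter), and neither of these two compounds goes against it. No supporting data bear on what lies behind these numbers.

Still open, from the compounds shown here alone, is whether a morpholine ring on the same saturated chain carbon would stay level with compound 2 and compound 4. Going by these compounds, it is equally open whether a methoxymethyl group, which has no amine nitrogen, in place of chloro on the aromatic carbon would stay level with them or remain close to compound 1.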